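The source may report more compounds than this note shows. Statements on the series, on what has been measured and on what is new or still open speak of the compounds shown alone.

Among the measured compounds shown here, in a functional assay on NCI-H522 cells (Homo sapiens) for cytotoxicity, with a stated time of 3 days (a lower number here means a stronger inhibitor, a higher number a weaker inhibitor), the three compounds measured so far read as follows.

compound 1 `Cn1c(I)nc2ccccc21` at 1020 nM
compound 2 `C#Cc1nc(C(=O)Nc2ccccc2)cs1` at 660 nM
compound 3 `C#Cc1nc(C(=O)N2CCN(c3ccc(F)cc3)CC2)cs1` at 64 nM

Compound 1 stands at the high end of these numbers, and compound 2 lies within the scatter of it. Compound 3 lies well below compound 1, beyond the scatter.

Compound 4 `Cn1c(Br)nc2ccccc21` has not yet been measured. It departs from compound 1 in one place (bromo in place of iodo on an aromatic carbon), with bromo in place of iodo on an aromatic carbon, and the rest of the structure stays the same. For the measured compounds named here, no pair of measured compounds shows this exchange, so the data give no direct size for it. In this assay no step beyond the scatter is expected, in either direction. The expectation therefore rests on compound 1 at 1020 nM as its anchor, with a wide margin. The expected change is a 1.2-fold higher number from compound 1 to compound 4 (0.07 log units; within the scatter) and remains an estimate. Compound 4 is estimated at 1200 nM with an expected range from 450 nM to 3500 nM in this measurement.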

Compound 4, half-maximal inhibitory concentration: > 40000 nM
Compound 4: no number, only a limit; the forecaster's own chance of this, stated with the estimate: 10%; middle value at least 33-fold (1.52 log units) away from the limit.
By their numbers in this assay, from the lowest: compound 3; then compounds 2 and 1 (each within the scatter of the next). At a limit, above all of these: compound 4.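

In this assay, the shared core of compound 1 turns out not to tolerate every halogen equally at the aromatic carbon between two ring nitrogen atoms: bromo in place of iodo gives an at least 39-fold higher number from compound 1 to compound 4 (1.59 log units; beyond the scatter). A change of one heavy atom, with no ring, hydrogen-bond donor, hydrogen-bond acceptor or net charge entering or leaving, is thus enough to produce a step beyond the scatter. Compound 4 has only a limit, > 40000 nM, so the step gives a minimum size and not a true size: the limit of > 40000 nM in this assay, at which 1 of the 4 values shown sits.

The compounds shown leave open whether any group other than iodo at this position, such as chloro, a nitrile or an amine, would give a measurable number. They also leave open whether the exchange would have a similar effect if the methyl group gave way to a longer chain.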